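The compounds below may be only part of what the source reports. "The series", "measured", "known", "first", "only" and "open" are said of these compounds alone.

Compound 1: `O=C(NC1CCCCC1)Oc1cccc(-c2cccc(Oc3ccccc3)c2)c1` — 420 nM
Compound 2: `O=C(NC1CCCCC1)Oc1cccc(-c2cccc(Cc3ccccc3)c2)c1` — 1860 nM

In an assay on cell membranes for binding affinity to Fatty-acid amide hydrolase 1 (Rattus norvegicus) (on this read-out higher numbers stand for weaker inhibition and lower numbers for stronger inhibition), compound 2 gives the highest of the two numbers, with compound 1 giving a lower one, and the step of a 4.4-fold higher number from compound 1 to compound 2 (0.65 log units; beyond the scatter) lies beyond the scatter. Compound 3 is `O=C(NC1CCCCC1)Oc1cccc(-c2cccc([N+](=O)[O-])c2)c1`. It differs from compound 2 by nitro in place of benzyl on an aromatic carbon. Within the data shown here, no measured step swaps a benzyl for a nitro, so the only guide is the modest size of the phenoxy-to-benzyl change. The step is therefore expected to be a 1.2-fold lower number from compound 2 to compound 3 (0.09 log units; within the scatter), in either direction or none beyond the scatter. Compound 3 is estimated at 1500 nM, within 300 nM to 8000 nM.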

Compound 3, half-maximal inhibitory concentration: 49.6 nM
Beside the measured number, compound 3's estimate is 30-fold (1.48 log units) above it; the whole stated range lies above it.
By their numbers in this assay, from the lowest: compound 3; then compound 1; then compound 2.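

In this assay, nitro in place of benzyl gives a 38-fold lower number from compound 2 to compound 3 (1.57 log units; beyond the scatter), and nitro in place of phenoxy gives an 8.5-fold lower number from compound 1 to compound 3 (0.93 log units; beyond the scatter). At this position, then, a group carrying an aromatic ring is not needed for the lowest number of the three, and swapping either ring-bearing group for nitro moves the number further than swapping one for the other. No measurement at hand accounts for this. As far as these compounds go, whether nitro itself matters, or any group without a ring would do the same, stays open; a nitrile, an amine or a carboxylic acid at this position would help settle it.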